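The source may hold more compounds than are shown below. What is called first, only, known or untested is meant among the compounds shown, and "the series" means these compounds.

In an ADME assay on HepG2 cells (Homo sapiens) for cytotoxicity, read by MTT assay, with a stated time of 72 h (on this read-out lower numbers stand for higher toxicity in this test and higher numbers for lower toxicity in this test), the measured compounds stand as follows:
Compound 1 `O=[N+]([O-])c1cnc2c(Br)cc(Cl)cn12` - 16200 nM
Compound 2 `O=[N+]([O-])c1c(CS(=O)(=O)c2ccccc2)nc2c(Nc3ccc(Cl)cc3)cc(Cl)cn12` - > 3900 nM (a limit)
Compound 3 `O=[N+]([O-])c1cnc2c(Sc3ccc(Cl)cc3)cc(Cl)cn12` - > 7800 nM (a limit)

Among the compounds with values here, compound 1 holds the only real number, at 16200 nM on this scale. Compound 2 gives only a limit of the assay (> 3900 nM). Compound 3 likewise gives only a limit (> 7800 nM).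

Compound 4 `CS(=O)(=O)Cc1nc2c(Br)cc(Cl)cn2c1[N+](=O)[O-]` has not yet been measured. It carries (methylsulfonyl)methyl in place of hydrogen on an aromatic carbon of the core of compound 1 ((methylsulfonyl)methyl in place of hydrogen on an aromatic carbon). Within the data shown here, no measured pair shows this change alone, so in this assay only a small step is expected, perhaps none beyond the usual scatter, leaning toward lower toxicity. The estimated move (a 1.2-fold higher number from compound 1 to compound 4 (0.09 log units; within the scatter)) is modest. The estimate for compound 4 is 20000 nM with an expected range from 7000 nM to 60000 nM at its two ends.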

Compound 4, half-maximal cytotoxic concentration: 45000 nM
For compound 4 the middle estimate is 2.3-fold (0.35 log units) below the measured one; the measured number falls inside the stated range.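

Putting (methylsulfonyl)methyl in place of hydrogen on this aromatic carbon gives a 2.8-fold higher number from compound 1 to compound 4 (0.44 log units; beyond the scatter) in this assay and so shifts the read-out toward lower toxicity in this test. Within the data shown here, this is the only step at this position with real numbers at both ends, since compound 2 gives only a limit. Nothing shown here accounts for the shift.

On these data alone, whether a plain methyl, an amine or a carboxylic acid on a longer chain at this position would move the number the same way remains open.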